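This account rests on a few compounds, and the source may have more. Where it says the series, first, only, none or still open, it means among the compounds named here.

In a functional assay on isolated protein with Glucose-dependent insulinotropic receptor (Mus musculus) as the target, read by HTRF and cAMP accumulation, with a stated time of 45 min (a lower number here means a smaller maximal response, a higher number a larger maximal response), compound 2 `C[C@@H]1CN(C(=O)OC(C)(C)C)CCN1c1ncc(OCc2ccc(C#N)cc2)cn1` gives 88%, the higher of the two measured numbers, while compound 1 `C[C@@H]1CN(C(=O)OC(C)(C)C)CCN1c1ncc(OCc2ccc(S(=O)(=O)N(C)C)cc2)cn1` gives 39%. Compound 3 `C[C@@H]1CN(C(=O)OC(C)(C)C)CCN1c1ncc(OCc2ccc(-n3cnnn3)cc2)cn1` carries the change (1H-tetrazol-1-yl in place of cyano on an aromatic carbon). Among the compounds with values here, no measured step covers this exchange; the only step bearing on it, a number 49 percentage points higher from compound 1 to compound 2 (beyond the scatter), shows that exchanging the group on this aromatic carbon can shift the response strongly. A sizeable step is therefore expected in this assay, more likely downward than upward, with wide uncertainty. Compound 3 is expected to give 60%, between 30% and 95%. The expected step is a number 28 percentage points lower from compound 2 to compound 3 (beyond the scatter).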

Compound 3, intrinsic activity: the largest response reached, in percent of the reference agonist's: 115%
Compound 3: the middle estimate sits 55 percentage points below what was measured, and the stated range ends below it.
By their numbers in this assay, from the lowest: compound 1; then compound 2; then compound 3.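

In this assay, the 1H-tetrazol-1-yl group on this aromatic carbon gives a response that passes that of the cyano group (a number 27 percentage points higher from compound 2 to compound 3 (beyond the scatter)) and lies far from that of the dimethylsulfamoyl group (a number 76 percentage points higher from compound 1 to compound 3 (beyond the scatter)). The cyano group therefore does not mark the upper end of the response at this position, and a five-membered aromatic ring with 4 hetero atoms is accepted here without loss. Nothing available explains the order of these three groups.

From the compounds shown here alone, what a carboxylic acid, a primary amide or a 1,2,3-triazol-1-yl group would give on this carbon remains open. So does whether the gain from the 1H-tetrazol-1-yl group persists when the tert-butyl carbamate is exchanged for another group.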